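Swapping methyl(tert-butyl)amino for (carboxymethyl)amino on the side chain

A few compounds are considered here, and "the series" means these few. Any claim that something is new, unique, unknown or untested is made for them only; others in the source may bear on it.

In a functional assay on MCF7 cells (Homo sapiens) for antiproliferative activity (a lower number here means a stronger inhibitor, a higher number a weaker inhibitor), compound 3 `CC(C)=CCc1cc(C(=O)Nc2cc3ccc(OCCCN(C)C(C)(C)C)c(C)c3oc2=O)ccc1O` gives 1140 nM. This lies within the scatter of compound 1 `CC(C)=CCc1cc(C(=O)Nc2cc3ccc(OCC4CCCNC4)c(C)c3oc2=O)ccc1O` at 790 nM. Compound 2 `CCN(CC)CCCOc1ccc2cc(NC(=O)c3ccc(O)c(CC=C(C)C)c3)c(=O)oc2c1C` stands further off at 6390 nM. Compound 4 `CC(C)=CCc1cc(C(=O)Nc2cc3ccc(OCCCNCC(=O)O)c(C)c3oc2=O)ccc1O` differs from compound 3 in one place: (carboxymethyl)amino in place of methyl(tert-butyl)amino on a saturated chain carbon, three bonds along the chain from an oxygen on an aromatic ring. The new group, (carboxymethyl)amino, sits on a saturated chain carbon, three bonds along the chain from an oxygen on an aromatic ring. For the measured compounds named here, the closest precedent is a swap of amino groups at that same place, a 5.6-fold lower number from compound 2 to compound 3 (0.75 log units; beyond the scatter). Changes in this region also gave an 8.1-fold higher number from compound 1 to compound 2 (0.91 log units; beyond the scatter) and a 1.4-fold higher number from compound 1 to compound 3 (0.16 log units; within the scatter). None of these compounds carries a carboxymethyl group, so the direction is uncertain. A modest rise is expected, a 2.6-fold higher number from compound 3 to compound 4 (0.42 log units; beyond the scatter). For compound 4 the estimated value is 3000 nM, with an expected range of 800 nM to 12000 nM.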

Compound 4, half-maximal inhibitory concentration: 18100 nM
For compound 4 the middle estimate is 6.0-fold (0.78 log units) below the measured one; the measured number lies above the stated range.
By their numbers in this assay, from the lowest: compounds 1 and 3 (each within the scatter of the next); then compound 2; then compound 4.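

In this assay, this place on the chain tolerates less than the earlier amines suggested: (carboxymethyl)amino gives a 16-fold higher number from compound 3 to compound 4 (1.20 log units; beyond the scatter), a larger step than any among compounds 1, 2 and 3. The same group also gives a 2.8-fold higher number from compound 2 to compound 4 (0.45 log units; beyond the scatter) and a 23-fold higher number from compound 1 to compound 4 (1.36 log units; beyond the scatter), so compound 4 has the highest number of the four, beyond the scatter of each. No measurement shown accounts for this rise.

From the compounds shown here alone, whether the step follows the carboxylic acid itself remains open. A methyl ester or a primary amine at the same place would test that.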